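The source may report more compounds than this note shows. Statements on the series, on what has been measured and on what is new or still open speak of the compounds shown alone.

Measured in a functional assay on HepG2 cells (Homo sapiens) for antiproliferative activity, read by MTT assay, with a stated time of 24 h; a higher number here means a weaker inhibitor, a lower number a stronger inhibitor:
- compound 1 `Cc1ccc(-c2nn(-c3ccccc3)cc2-c2nc3ccccc3n2S(=O)(=O)c2cc(C)ccc2C)cc1` at 460 nM
- compound 2 `O=S(=O)(c1ccccc1)n1c(-c2cn(-c3ccccc3)nc2-c2ccc(F)cc2)nc2ccccc21` at 720 nM
- compound 3 `COc1ccc(S(=O)(=O)n2c(-c3cn(-c4ccccc4)nc3-c3ccc(F)cc3)nc3ccccc32)cc1` at 470 nM

These three numbers all lie within the scatter of one another. Compound 3 at 470 nM has compound 1 as its nearest neighbour and compound 2 as its furthest, and neither gap goes beyond the scatter.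

Compound 4 `Cc1ccc(C)c(S(=O)(=O)n2c(-c3cn(-c4ccccc4)nc3-c3ccc(F)cc3)nc3ccccc32)c1` has not yet been measured. It differs from compound 3 in one place, with 2,5-dimethylphenyl in place of 4-methoxyphenyl on a sulfonyl sulfur.

Among the measured compounds shown here, one measured step bears on this group: a 1.5-fold lower number from compound 2 to compound 3 (0.19 log units; within the scatter) with methoxy in place of hydrogen on an aromatic carbon. That step stays within the scatter. Though it differs from compound 4 elsewhere, compound 1 already carries 2,5-dimethylphenyl on its sulfonyl sulfur, and compound 1 gives 460 nM in the same test. For the measured compounds named here, no measured pair isolates this exact exchange, so no step beyond the scatter is expected in this assay and no direction is favoured. The expected change is a 1.0-fold lower number from compound 3 to compound 4 (0.01 log units; within the scatter) and would stay within the scatter. For compound 4 the estimated value is 460 nM with an expected range from 240 nM to 900 nM in this test.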

Compound 4, half-maximal inhibitory concentration: 410 nM
Beside the measured number, compound 4's estimate is 1.1-fold (0.05 log units) above it; the range from low to high includes it.
By their numbers in this assay, from the lowest: compounds 4, 1, 3 and 2 (each within the scatter of the next).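

On the core shared by compound 2, compound 3 and compound 4, the sulfonyl sulfur has now carried phenyl, 4-methoxyphenyl and 2,5-dimethylphenyl in this assay, and the entry of 2,5-dimethylphenyl stays within the scatter against both other groups (a 1.1-fold lower number from compound 3 to compound 4 (0.06 log units; within the scatter); a 1.8-fold lower number from compound 2 to compound 4 (0.24 log units; within the scatter)). Among the compounds shown here, with 2,5-dimethylphenyl held on the sulfonyl sulfur, the result also gives the first reading of a change elsewhere in the molecule, fluoro in place of methyl on an aromatic carbon, and this too stays within the scatter (a 1.1-fold lower number from compound 1 to compound 4 (0.05 log units; within the scatter)). The exchange at the sulfonyl sulfur replaces a group with one hydrogen-bond acceptor by one with none without a step beyond the scatter, and nothing available explains these numbers.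

All the groups shown on the sulfonyl sulfur are six-membered aromatic rings of carbon only, with methyl or methoxy as their only substituents. Going by these compounds, it remains open whether an amine or a carboxylic acid on that ring, or a longer alkyl chain in place of the ring, would give a step beyond the scatter in this assay.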